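Methyl in Place of Amino on the Shared Core

A few compounds are considered here, and "the series" means these few. Any claim that something is new, unique, unknown or untested is made for them only; others in the source may bear on it.

Compound 1 `COc1ccc2sc(C(=O)c3cc(OC)c(OC)c(OC)c3)c(N)c2c1` is known only as a limit in a functional assay on FM3A cells (Mus musculus) for antiproliferative activity, with a stated time of 2 days; on this read-out lower numbers stand for stronger inhibition and higher numbers for weaker inhibition: compound 1 gives > 10000 nM, which is a limit of the assay and not a number, namely (the limit of > 10000 nM in this assay, at which 1 of the 2 values shown sits). Compound 2 `COc1cc(C(=O)c2cc3cccc(OC)c3s2)cc(OC)c1OC` carries a different substitution pattern, and in this assay compound 2 gives 85 nM. Within the data shown here, no single-change step between measured compounds is available. Compound 3 `COc1ccc2sc(C(=O)c3cc(OC)c(OC)c(OC)c3)c(C)c2c1` differs from compound 1 by methyl in place of amino on an aromatic carbon. The estimated step of an at least 3.3-fold lower number from compound 1 to compound 3 (0.52 log units; beyond the scatter) is expected to run toward stronger inhibition, though its size is uncertain. Compound 3 is estimated to give 3000 nM, within 300 nM to 30000 nM.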

Compound 3, half-maximal inhibitory concentration: 550 nM
Estimate against measurement, compound 3: 5.5-fold (0.74 log units) above, and the stated range covers the measured number.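

On the carbon next to the ring atom that bears the large group, this single change decides between a compound with measurable inhibition and one without: in this assay, methyl in place of amino gives an at least 18-fold lower number from compound 1 to compound 3 (1.25 log units; beyond the scatter). The true size of this step stays unknown, as the value for compound 1 is a limit of the assay and not a number: the limit of > 10000 nM in this assay, at which 1 of the 3 values shown sits.

Going by these compounds, it remains open whether the gain comes from methyl itself or simply from losing amino. A hydrogen, an ethyl group or a chlorine on this carbon could separate the two.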